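This account rests on a few compounds, and the source may have more. Where it says the series, first, only, none or still open, it means among the compounds named here.

In this assay, within the data shown here, only two compounds have been measured so far. In a functional assay on BXPC-3 cells (Homo sapiens) for inhibition, read by MTT assay, with a stated time of 7 days (on this read-out higher numbers stand for weaker inhibition and lower numbers for stronger inhibition), compound 1 `CCOC(=O)[C@@H]1CCCN(S(=O)(=O)c2ccc(S(=O)(=O)N(C)C)cc2)C1` gives 1000 nM, while compound 2 `CCOC(=O)[C@@H]1CCCN(S(=O)(=O)c2ccc(C(=O)N(CC)CC)cc2)C1` gives 640 nM. Among the measured compounds shown here, compound 2 thus carries the lowest of the two numbers, but its only neighbour is compound 1, and the difference a 1.6-fold lower number from compound 1 to compound 2 (0.19 log units; within the scatter) is too small to separate them. Compound 3 `CCCN(CC)S(=O)(=O)c1ccc(S(=O)(=O)N2CCC[C@@H](C(=O)OCC)C2)cc1` has not yet been measured. It differs from compound 2 in a single place: ethyl(propyl)sulfamoyl in place of diethylcarbamoyl on an aromatic carbon. For the measured compounds named here, the one measured step that bears on this change exchanged a dimethylsulfamoyl for a diethylcarbamoyl at the same aromatic carbon, and that exchange stayed within the scatter. A return to a sulfamoyl, now carrying ethyl and propyl chains, is therefore expected to give no step beyond the scatter in this assay. For compound 3 the estimate is 800 nM, with a likely range from 350 nM to 1900 nM, meaning an expected step of a 1.3-fold higher number from compound 2 to compound 3 (0.10 log units; within the scatter).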

Compound 3, half-maximal inhibitory concentration: 300 nM
Beside the measured number, compound 3's estimate is 2.7-fold (0.43 log units) above it, outside the stated range (below it).
By their numbers in this assay, from the lowest: compound 3; then compounds 2 and 1 (each within the scatter of the next).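

In this assay, a change at this aromatic carbon now gives a step beyond the scatter: ethyl(propyl)sulfamoyl in place of diethylcarbamoyl gives a 2.1-fold lower number from compound 2 to compound 3 (0.33 log units; beyond the scatter). A sulfamoyl group alone does not go with the lower number, since compound 1 also carries one and lies within the scatter of compound 2, whereas ethyl(propyl)amino in place of dimethylamino on the sulfonyl sulfur gives a 3.3-fold lower number from compound 1 to compound 3 (0.52 log units; beyond the scatter). The chains on the sulfamoyl nitrogen therefore make a measurable difference within this set, but no measurement here explains why.

From the compounds shown here alone, it remains open whether the ethyl chain, the propyl chain or both are needed, and whether a longer chain such as butyl would lower the number further. A piperidine ring on the sulfonyl sulfur, or a carboxylic acid in place of the ethyl ester on the shared core, also remains untested among the compounds shown.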